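Carboxy(phenyl)methyl on the Aniline Nitrogen of Compound 2

The source may hold more compounds than are shown below. What is called first, only, known or untested is meant among the compounds shown, and "the series" means these compounds.

Three compounds have been measured in a functional assay on DU-145 cells (Homo sapiens) for cytotoxicity, read by trypan blue exclusion, with a stated time of 96 h; a lower number here means a stronger inhibitor, a higher number a weaker inhibitor:
compound 1 `COc1ccc(CS(=O)(=O)/C=C/c2c(OC)cccc2OC)cc1N`, giving 50 nM
compound 2 `COc1cc(OC)c(/C=C/S(=O)(=O)Cc2ccc(OC)c(N)c2)c(OC)c1`, giving 4 nM
compound 3 `COc1cc(OC)c(/C=C/S(=O)(=O)Cc2ccc(Br)c(N)c2)c(OC)c1`, giving 750 nM

Compound 2 stands lowest of the three. Its nearest neighbour is compound 1, separated by a 13-fold lower number from compound 1 to compound 2 (1.10 log units; beyond the scatter); the furthest is compound 3, reached by a 190-fold higher number from compound 2 to compound 3 (2.27 log units; beyond the scatter). Both measured steps alter the aromatic carbon that carries methoxy, and both are large. Compound 4 `COc1cc(OC)c(/C=C/S(=O)(=O)Cc2ccc(OC)c(NC(C(=O)O)c3ccccc3)c2)c(OC)c1` changes a different place: carboxy(phenyl)methyl in place of hydrogen on a nitrogen on an aromatic ring. For the measured compounds named here, no measured step touches this nitrogen, so the two known steps bear on it only indirectly, showing that the ring bearing the amino group tolerates little change. A drop in potency, in this assay, is therefore expected, though of uncertain size. Compound 4 is expected to give about 40 nM, between 8 nM and 250 nM. The estimated step of a 10-fold higher number from compound 2 to compound 4 (1.00 log units; beyond the scatter) is expected to lie beyond the scatter.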

Compound 4, half-maximal inhibitory concentration: 20 nM
The estimate for compound 4 lay 2.0-fold (0.30 log units) above the measured number; the range from low to high includes it.
By their numbers in this assay, from the lowest: compound 2; then compound 4; then compound 1; then compound 3.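

In this assay, this nitrogen accepts a large substituent: carboxy(phenyl)methyl in place of hydrogen gives a 5.0-fold higher number from compound 2 to compound 4 (0.70 log units; beyond the scatter), a modest step though beyond the scatter. The earlier steps shown here changed only aromatic carbons, and the bromo change gave the much larger a 190-fold higher number from compound 2 to compound 3 (2.27 log units; beyond the scatter). Carboxy(phenyl)methyl added on the amino nitrogen thus weakens the number far less than that single exchange on the ring.

As far as these compounds go, whether a plain benzyl group or a carboxymethyl group on this nitrogen would give a similar number remains open. No evidence is available to explain the size of this step.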